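Amino substitution on the thiazole-bearing series against lysine demethylase 5C

The source may hold more compounds than are shown below. What is called first, only, known or untested is meant among the compounds shown, and "the series" means these compounds.

Compound 1 `Nc1nc(-c2cc(C(=O)O)ccn2)cs1`, compound 2 `O=C(O)c1ccnc(-c2cscn2)c1` and compound 3 `O=c1[nH]cnc2c(-c3cscn3)nccc12` have been run in an assay on isolated protein for inhibition of lysine-specific demethylase 5C (Homo sapiens), read by AlphaScreen, with stated times of 15 min and 20 min; on this read-out higher numbers stand for weaker inhibition and lower numbers for stronger inhibition. In this assay compound 1 gives 12 nM, compound 2 gives 122 nM and compound 3 gives 830 nM, the highest of the three numbers.

Compound 1 and compound 2 differ in one place, (amino in place of hydrogen on an aromatic carbon). The step is a 10-fold lower number from compound 2 to compound 1 (1.01 log units; beyond the scatter). Compound 4 `Nc1nc(-c2nccc3c(=O)[nH]cnc23)cs1`, not yet measured, carries the same kind of change on the core of compound 3: amino in place of hydrogen on an aromatic carbon. The two place descriptions agree except that in the pair of compound 2 and compound 1 the ring atom two ring bonds away bears a group of 9 heavy atoms, whereas in the pair of compound 3 and compound 4 it bears a large group. The difference between the core of compound 2 and the core of compound 3 is not broken down here; the two values alone show that compound 3 sits well above compound 2.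

Compound 4 is expected to come in at 100 nM in this assay, between 40 nM and 300 nM. Among the compounds with values here, the expected step of an 8.3-fold lower number from compound 3 to compound 4 (0.92 log units; beyond the scatter) rests on the single measured precedent, the step of a 10-fold lower number from compound 2 to compound 1 (1.01 log units; beyond the scatter), transferred to a different core; the transfer is the main source of uncertainty, since the same kind of change on the core of compound 3 has not been measured before.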

Compound 4, half-maximal inhibitory concentration: 331 nM
The estimate for compound 4 lay 3.3-fold (0.52 log units) below the measured number, outside the stated range (above it).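

Amino in place of hydrogen on an aromatic carbon again lowers the number in this assay on the core of compound 3, where the step is a 2.5-fold lower number from compound 3 to compound 4 (0.40 log units; beyond the scatter), so the direction of the change carries over from the core of compound 2 and the step remains beyond the scatter. The size of the step does not carry over, and the amino change cannot be treated as a fixed increment across these cores: the same change on two cores in this assay, a 10-fold lower number (1.01 log units; beyond the scatter) from compound 2 to compound 1 and a 2.5-fold lower number (0.40 log units; beyond the scatter) from compound 3 to compound 4, 4.1-fold (0.61 log units) apart, beyond the scatter of two such steps
Within the data shown here, with only one pair of compounds on each core, these data do not show which feature of the cores goes with the larger or smaller step, nor what size the step would take on any further core.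

Still open, as far as these compounds go, is whether other groups on the same aromatic carbon, such as methylamino or acetamido, would follow the amino group on both cores or give steps that differ between them. Also open, from the compounds shown here alone, is which part of the difference between the core of compound 2 and the core of compound 3 goes with the change in step size, including whether a carboxylic acid or a primary amide on the core of compound 3 would restore the larger step.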